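The source may report more compounds than this note shows. Statements on the series, on what has been measured and on what is new or still open speak of the compounds shown alone.

Working notes on the series. The shared core is a bicyclic amide scaffold carrying an anilide side chain. Compound 1 `O=C(Nc1ccccc1C(F)(F)F)C1CCc2ccccc2N1C(=O)c1ccccc1` bears a trifluoromethyl group on the anilide ring and a benzoyl group on the ring nitrogen; in a functional assay on HCT-15 cells (Homo sapiens) for cytotoxicity, read by sulforhodamine B assay, with a stated time of 72 h (a higher number here means a weaker inhibitor of growth, a lower number a stronger inhibitor of growth), compound 1 gives 6500 nM. Among the compounds with values here, compound 2 `COc1ccc(NC(=O)C2CCc3ccccc3N2)cc1` has the unsubstituted ring nitrogen and a methoxy group on the anilide ring; in this assay compound 2 gives 50200 nM, the highest of the two numbers so far, with compound 1 as its nearest neighbour at a markedly lower number, a gap beyond the scatter.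

Compound 3 `O=C(Nc1ccccc1)C1CCc2ccccc2N1` is the next step from compound 2. Change: hydrogen in place of methoxy on an aromatic carbon. Within the data shown here, no measured pair shows this change on its own, so its effect is not anchored by a measured step; compound 1 differs at two places at once and cannot be read as a guide to it. The expectation is a step of no more than the scatter, in either direction, with the estimate for the step from compound 2 to compound 3 at a 1.3-fold lower number from compound 2 to compound 3 (0.10 log units; within the scatter). For compound 3 the expected value in this assay is 40000 nM, in the range 15000 nM to 120000 nM.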

Compound 3, concentration for 50% growth inhibition: 109000 nM
The estimate for compound 3 lay 2.7-fold (0.44 log units) below the measured number; the range from low to high includes it.
By their numbers in this assay, from the lowest: compound 1; then compound 2; then compound 3.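

Within the data shown here, the first step that can be read at a single place concerns the methoxy group on an aromatic carbon of a six-membered aromatic ring of carbon only, para to a large group. In this assay, hydrogen in place of methoxy gives a 2.2-fold higher number from compound 2 to compound 3 (0.34 log units; beyond the scatter), so a change at this position alone moves the number, modestly but beyond the scatter, and the methoxy-bearing compound is the stronger inhibitor of growth of this pair. Nothing at hand accounts for the direction or size of this step.

The compounds shown leave open whether another group at this position, such as an amine, a hydroxyl group or a longer alkoxy chain, would give a lower number than methoxy or a higher one. Among these compounds, also open is whether hydrogen in place of methoxy would give a step of similar size and the same direction with a benzoyl group on the ring nitrogen, as compound 1 carries, because no pair with that group isolates this change.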